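This account rests on a few compounds, and the source may have more. Where it says the series, first, only, none or still open, it means among the compounds named here.

Three compounds sharing one core have numbers in a functional assay on L1210 cells (Mus musculus), with a stated time of 48 h; a lower number here means a stronger inhibitor, a higher number a weaker inhibitor. Compound 1 `CCOC(=O)Nc1cc(NC(C)C(=O)Cc2ccccc2)c([N+](=O)[O-])c(N)n1` gives 10000 nM, compound 2 `CCCCC(=O)C(C)Nc1cc(NC(=O)OCC)nc(N)c1[N+](=O)[O-]` gives 54000 nM, and compound 3 `CCCCC(Nc1cc(NC(=O)OCC)nc(N)c1[N+](=O)[O-])C(C)=O` gives 31000 nM. Compound 3 is therefore level with compound 2 within the scatter, while its number is higher than that of compound 1.

Compound 4 `CCCCC(Nc1cc(NC(=O)OCC)nc(N)c1[N+](=O)[O-])C(C)O` differs from compound 3 in one place: 1-hydroxyethyl in place of acetyl on a saturated chain carbon bound to a nitrogen on an aromatic ring and a saturated chain carbon. In words, this is 1-hydroxyethyl in place of acetyl on a saturated chain carbon bound to a nitrogen on an aromatic ring and a saturated chain carbon.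

Among the compounds with values here, no measured step makes this exact swap, but two touch the same side chain. One is a 5.4-fold higher number from compound 1 to compound 2 (0.73 log units; beyond the scatter), with propyl in place of phenyl. The other is a 1.7-fold lower number from compound 2 to compound 3 (0.24 log units; within the scatter), with 1-acetylpentyl in place of 1-(butylcarbonyl)ethyl. With so little to go on, no step beyond the scatter is expected in this assay, though the first of those steps argues for a wide range. The expected step is a 1.0-fold lower number from compound 3 to compound 4 (0.01 log units; within the scatter). For compound 4 the estimate is 30000 nM, within a range of 11000 nM to 80000 nM.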

Compound 4, half-maximal inhibitory concentration: 56000 nM
Compound 4: middle estimate off by 1.9-fold (0.27 log units), on the low side; measured number inside the range.
By their numbers in this assay, from the lowest: compound 1; then compounds 3, 2 and 4 (each within the scatter of the next).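

In this assay, 1-hydroxyethyl in place of acetyl on this saturated chain carbon gives a 1.8-fold higher number from compound 3 to compound 4 (0.26 log units; within the scatter), so the hydrogen-bond donor that 1-hydroxyethyl brings does not shift the number past the usual scatter. The wider change of 1-(1-hydroxyethyl)pentyl in place of 1-(butylcarbonyl)ethyl on the aromatic ring's nitrogen gives a 1.0-fold higher number from compound 2 to compound 4 (0.02 log units; within the scatter), which also leaves the number within the scatter. In these compounds, then, the carbonyl of the acetyl is not needed to keep the number at this level, and no information is available on why the swap changes so little.

Still open, as far as these compounds go, is whether an amine or a carboxylic acid in place of acetyl at this position would give a step beyond the scatter. A longer chain, such as 1-hydroxypropyl in place of 1-hydroxyethyl, is equally untested among the compounds shown.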